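Shortening a Side Chain in a Purine Amide Series

A few compounds are considered here, and "the series" means these few. Any claim that something is new, unique, unknown or untested is made for them only; others in the source may bear on it.

Measured so far:
compound 1, `NC(=O)C[C@H](NC(=O)CN(c1nc(Cl)nc2[nH]cnc12)C1CC1)C(=O)O`, 7.51%
compound 2, `O=C(O)CNC(=O)CN(c1nc(Cl)nc2[nH]cnc12)C1CC1`, 9.08%
compound 3, `NC(=O)CC[C@H](NC(=O)CN(c1nc(Cl)nc2[nH]cnc12)C1CC1)C(=O)O`, 11.4%

All three share a core built on a chlorinated purine carrying a cyclopropyl group, with an amino acid attached through an amide. They were tested in a functional assay on the whole organism (Tail, strain ICR) with Mus musculus as the target, in the tail flick test, with a stated time of 150 min, at a dose of 25 umol/kg by the oral route; a higher number here means a stronger effect of the compound at the dose given, a lower number a weaker effect. The three values lie close together: the step of a number 1.6 percentage points higher from compound 1 to compound 2 (within the scatter), the step of a number 3.9 percentage points higher from compound 1 to compound 3 (within the scatter) and the step of a number 2.3 percentage points higher from compound 2 to compound 3 (within the scatter) all fall within the usual scatter.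

Compound 4, `C[C@H](NC(=O)CN(c1nc(Cl)nc2[nH]cnc12)C1CC1)C(=O)O`, has not yet been measured. It differs from compound 3 by hydrogen in place of carbamoylmethyl on a saturated chain carbon, two bonds along the chain from an amide-type nitrogen and a carbonyl carbon. The same kind of change, (hydrogen in place of carbamoylmethyl on a saturated chain carbon bound to an amide-type nitrogen and a carbonyl carbon), links compound 1 and compound 2, where it gave the step of a number 1.6 percentage points higher from compound 1 to compound 2 (within the scatter). It is the same kind of change rather than the same one, since in compound 1 the group sits on a saturated chain carbon bound to an amide-type nitrogen and a carbonyl carbon, while in compound 3 it sits two bonds along the chain from those atoms. The two cores also differ by carbamoylmethyl in place of carbamoyl on a saturated chain carbon, two bonds along the chain from an amide-type nitrogen and a carbonyl carbon.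

Because the earlier step of a number 1.6 percentage points higher from compound 1 to compound 2 (within the scatter) stayed within the scatter, the step of a number 0.9 percentage points lower from compound 3 to compound 4 (within the scatter) is expected to be equally small. Compound 4 is therefore estimated at 10.5%, with a likely range from 3% to 19%.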

Compound 4, a percentage reported as activity, at one dose (the size of the read-out at that dose, not a potency): 14.7%
The estimate for compound 4 lay 4.2 percentage points below the measured number; the measured number falls inside the stated range.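

In this assay, the new steps are a number 3.3 percentage points higher from compound 3 to compound 4 (within the scatter), a number 5.6 percentage points higher from compound 2 to compound 4 (within the scatter) and a number 7.2 percentage points higher from compound 1 to compound 4 (within the scatter), so none of them stands out from the usual noise of this kind of test. Replacing carbamoylmethyl with hydrogen looks much the same on both cores, with no detectable difference between the two cases: the same change on two cores in this assay, a number 1.6 percentage points higher (within the scatter) from compound 1 to compound 2 and a number 3.3 percentage points higher (within the scatter) from compound 3 to compound 4, 1.7 percentage points apart, within the scatter of two such steps

For the compounds shown here, this shows only that the change made no step larger than the scatter on either core, so carrying it from one core to the other gave no surprise; it does not show that the change has a real effect on either core, or that the same would hold on a third core. Going by these compounds alone, with only two such pairs, each read at one dose, nothing can be said about potency.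

The compounds shown leave open whether an amine, a side-chain carboxylic acid or a longer hydrocarbon chain in place of carbamoylmethyl would give a step beyond the scatter. They also leave open what would happen if a different group replaced the cyclopropyl or the chlorine on the shared core.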